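The source may hold more compounds than are shown below. What is called first, only, known or untested is meant among the compounds shown, and "the series" means these compounds.

Values in an ADME assay on liver for metabolic stability, with Liver microsome (Homo sapiens) as the target, using microsomes; a higher number here means faster removal of the compound, a lower number slower removal:
compound 1 `O=C(Nc1cc(-c2ccccn2)n[nH]1)N1CCC(c2ccc(Cl)cc2)CC1`: 30 mL.min-1.g-1
compound 2 `O=C(Nc1cc(-c2ccccn2)n[nH]1)N1CCC(Oc2ccccc2)CC1`: 27.3 mL.min-1.g-1

Among the measured compounds shown here, compound 1 and compound 2 lie within the scatter of each other; the one step in this assay, a 1.1-fold lower number from compound 1 to compound 2 (0.04 log units; within the scatter), is within the scatter. Compound 3 `O=C(Nc1cc(-c2ccccn2)n[nH]1)N1CCC(c2ccccc2)CC1` differs from compound 1 by hydrogen in place of chloro on an aromatic carbon. For the measured compounds named here, no measured step removes a chloro; the only step seen, phenoxy in place of 4-chlorophenyl, was within the scatter. For compound 3 no step beyond the scatter is therefore expected, an estimated 1.1-fold lower number from compound 1 to compound 3 (0.05 log units; within the scatter). Compound 3 is estimated at 27 mL.min-1.g-1, between 14 mL.min-1.g-1 and 52 mL.min-1.g-1.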

Compound 3, intrinsic clearance in microsomes: 15.3 mL.min-1.g-1
Estimate against measurement, compound 3: 1.8-fold (0.25 log units) above; measured number inside the range.
By their numbers in this assay, from the lowest: compounds 3, 2 and 1 (each within the scatter of the next).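

In this assay, hydrogen in place of chloro on the aromatic carbon para to a large group gives a 2.0-fold lower number from compound 1 to compound 3 (0.29 log units; within the scatter), and phenyl in place of phenoxy gives a 1.8-fold lower number from compound 2 to compound 3 (0.25 log units; within the scatter). Both steps lie within the scatter, so neither change separates these compounds from one another. Nothing at hand bears on the origin of these steps.

As far as these compounds go, whether a fluoro or an amine at that aromatic carbon, or a carboxylic acid there, would give a step beyond the scatter remains open.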